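The source may report more compounds than this note shows. Statements on the series, on what has been measured and on what is new or still open speak of the compounds shown alone.

Compound 2 is `COc1cc(CNC(=S)NC(CCc2ccc(C(C)(C)C)cc2)COC(=O)C(C)(C)C)cc(I)c1O`, and in a functional assay on CHO cells for antagonist activity at transient receptor potential cation channel subfamily V member 1 (Rattus norvegicus) (a higher number here means a weaker inhibitor, a lower number a stronger inhibitor), compound 2 gives 525 nM. For the measured compounds named here, that is the only number the set holds: compound 1, `COc1cc(CNC(=S)NC(CCc2ccc(C(C)(C)C)cc2)COC(=O)C(C)(C)C)ccc1O`, has no result in this assay, its entry reading "not evaluated" (no result reported), so compound 2 can be placed against nothing else and no step between measured compounds exists.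

Compound 3 is `COc1cc(CNC(=S)NC(CCc2ccc(C(C)(C)C)cc2)COC(=O)C(C)(C)C)c(Br)cc1O`. It differs from compound 2 in one place: 2-bromo-4-hydroxy-5-methoxyphenyl in place of 4-hydroxy-3-iodo-5-methoxyphenyl on a saturated chain carbon bound to an amide-type nitrogen. The halogen is thus moved and exchanged at the same time, the iodine on the ring carrying the hydroxy and methoxy groups giving way to a bromine elsewhere on that ring, while the rest of the molecule, the thiourea, the tert-butylphenyl chain and the pivalate ester, is unchanged.

Going by the values given here, with no comparable step in the data, the size of the step from compound 2 to compound 3 can only be guessed. The expectation is a loss of potency beyond the scatter, giving a 3.0-fold higher number from compound 2 to compound 3 (0.48 log units; beyond the scatter). Compound 3 is therefore expected to reach about 1600 nM in this assay, within a range of 400 nM to 6000 nM.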

Compound 3, inhibition constant: 76.1 nM
Estimate against measurement, compound 3: 21-fold (1.32 log units) above; the whole stated range lies above it.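

In this assay, the group on a saturated chain carbon bound to an amide-type nitrogen proves to be a place where potency responds to the halogen: 2-bromo-4-hydroxy-5-methoxyphenyl in place of 4-hydroxy-3-iodo-5-methoxyphenyl gives a 6.9-fold lower number from compound 2 to compound 3 (0.84 log units; beyond the scatter), and a lower number here means a stronger inhibitor. This change alters the identity of the halogen and its place on the ring together, while the two groups match in heavy-atom count, aromatic ring, hydrogen-bond donors and acceptors and net charge, so the step shows the combined effect of the exchange and cannot assign it to either part. Nothing available here bears on the reason for this difference.

The compounds shown leave open whether the stronger inhibition belongs to bromine itself or to the place it occupies, a question that a compound carrying iodine where compound 3 carries bromine would address. They also leave open how chlorine or a methyl group would compare in that same place, and whether the step would hold with a carboxylic acid in place of the pivalate ester.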